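Removing a methyl group from compound 3

The source may report more compounds than this note shows. Statements on the series, on what has been measured and on what is new or still open speak of the compounds shown alone.

compound 1 `N#Cc1ccc(NC(=O)c2cc(-c3ccncc3)ccc2O)cc1`: 7990 nM
compound 2 `N#Cc1ccc(NC(=O)c2cc(Cl)ccc2O)cc1`: 1860 nM
compound 3 `Cc1cccc(C(=O)Nc2ccc(C#N)cc2)c1O`: 8980 nM

All three values come from a functional assay on KG-1 cells (Homo sapiens) for cytotoxicity, read by luminescence and CellTiter-Glo, with a stated time of 3 days; a lower number here means a stronger inhibitor, a higher number a weaker inhibitor. The value of compound 3 lies within the scatter of that of compound 1, and both sit well above the value of compound 2.

Compound 4 `N#Cc1ccc(NC(=O)c2ccccc2O)cc1` has not yet been measured. It differs from compound 3 by one change, hydrogen in place of methyl on an aromatic carbon, ortho to a hydroxy group (hydrogen in place of methyl on an aromatic carbon).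

Within the data shown here, only one measured step offers any guide: a 4.3-fold lower number from compound 1 to compound 2 (0.63 log units; beyond the scatter). That modest step swaps other groups at a different aromatic carbon, so it shows only how far a single swap can move the number on this core. Among the measured compounds shown here, no measured pair shows the loss of a methyl group itself.

In this assay, a small move toward a lower number is therefore expected, probably staying within the scatter. The estimated step is a 1.8-fold lower number from compound 3 to compound 4 (0.25 log units; within the scatter). Compound 4 is expected to give about 5000 nM, with an estimated range from 1800 nM to 14000 nM.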

Compound 4, half-maximal inhibitory concentration: 5370 nM
The estimate for compound 4 lay 1.1-fold (0.03 log units) below the measured number; low and high end bracket the measured number.
By their numbers in this assay, from the lowest: compound 2; then compounds 4, 1 and 3 (each within the scatter of the next).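

In this assay, taking the methyl group off the aromatic carbon ortho to a hydroxy group gives a 1.7-fold lower number from compound 3 to compound 4 (0.22 log units; within the scatter) and so leaves the two compounds indistinguishable, which means this methyl group has no clear effect on the number in this cell assay. Compound 4 also gives the shared core a hydrogen baseline for the other substituted carbon: a 1.5-fold lower number from compound 1 to compound 4 (0.17 log units; within the scatter) shows that pyridin-4-yl there cannot be told apart from hydrogen, while a 2.9-fold higher number from compound 2 to compound 4 (0.46 log units; beyond the scatter) shows that chloro is the one group among those shown that stands clearly apart from hydrogen, on the stronger side. No measurement of any other kind is available that could explain these differences.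

As far as these compounds go, whether the position ortho to the hydroxy group tolerates every change, or only this small one, stays open, since an ethyl group, a longer chain or an amine on that carbon could behave quite differently from methyl. It is also unknown whether chloro on that same carbon would match the clear shift seen with chloro on the other carbon.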